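Swapping a pentyl chain for a methoxyphenyl ring

The compounds below may be only part of what the source reports. "The series", "measured", "known", "first", "only" and "open" are said of these compounds alone.

Three compounds share one core. Compound 1 `C=CCOc1ccc(C(=O)Nc2cccc(C)n2)cc1` and compound 2 `C=C(C)COc1ccc(C(=O)Nc2cccc(C)n2)cc1` carry short unsaturated chains on an oxygen, while compound 3 `CCCCCNc1cccc(NC(=O)c2ccc(OCCC)cc2)n1` carries a pentyl group on a ring nitrogen. In an in vitro assay on HEK-tsA201 cells for antagonist activity at Neuronal acetylcholine receptor; alpha3/beta4 (Homo sapiens), read by fluorescence and calcium flux (on this read-out lower numbers stand for stronger inhibition and higher numbers for weaker inhibition), compound 1 gives 31700 nM. Compound 2 gives 24700 nM, so the step of a 1.3-fold lower number from compound 1 to compound 2 (0.11 log units; within the scatter) says little. For compound 3 the assay reports no number but only a limit, > 100000 nM. For the measured compounds named here, compound 3 is thus the single value sitting at the limit of > 100000 nM in this assay, at which 1 of the 3 values shown sits, and where it stands beyond that limit is unknown.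

Compound 4 `CCCOc1ccc(C(=O)Nc2cccc(Nc3ccc(OC)cc3)n2)cc1` differs from compound 3 in one place: 4-methoxyphenyl in place of pentyl on a nitrogen on an aromatic ring. Going by the values given here, the only measured step, a 1.3-fold lower number from compound 1 to compound 2 (0.11 log units; within the scatter), concerns a chain on the oxygen and not the ring nitrogen, so no measured step bears on this change. Without such guidance, compound 4 is expected to stay weak; the estimated step of an at least 1.6-fold lower number from compound 3 to compound 4 (0.22 log units; that floor lies within the scatter) carries wide uncertainty. The estimate for compound 4 is 60000 nM, within a range from 15000 nM to 200000 nM, with a real chance that only a limit is reported again.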

Compound 4, half-maximal inhibitory concentration: > 100000 nM
Compound 4 was reported as a limit (the forecaster's own chance of this, stated with the estimate: 50%); at least 1.6-fold (0.22 log units) between middle value and limit.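

Compound 3 and compound 4 are both reported only as limits, so the step between them cannot be read: the limit of > 100000 nM in this assay, at which 2 of the 4 values shown sit. The compounds shown leave open how far either lies beyond that limit, and whether any group on that nitrogen gives a measurable value.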